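Removing a para chloro group: cytotoxicity in prostate cancer cells

The compounds below may be only part of what the source reports. "The series", "measured", "known", "first", "only" and "open" are said of these compounds alone.

Of the compounds shown here, three built on a shared core have been tested in a functional assay on DU-145 cells (Homo sapiens) for cytotoxicity, read by MTT assay; on this read-out lower numbers stand for stronger inhibition and higher numbers for weaker inhibition. Compound 3 `CC(O)(CSc1ccc(Cl)cc1)c1nc(-c2ccc(Cl)cc2)no1` gives 14500 nM. Compound 1 `CC(O)(CSc1ccc(Cl)cc1)c1nc(-c2ccccc2)no1` gives 70700 nM. Compound 2 `CC(O)(CS(=O)(=O)c1ccc(Cl)cc1)c1nc(-c2ccc(F)c(Cl)c2)no1` gives 35500 nM, which sits close to compound 1 and further from compound 3.

Compound 1 and compound 3 differ in one place: hydrogen in place of chloro on an aromatic carbon. That single exchange gave a 4.9-fold higher number from compound 3 to compound 1 (0.69 log units; beyond the scatter), so losing the chloro group weakened the effect on the cells by a modest but real margin.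

Compound 4 `CC(O)(CS(=O)(=O)c1ccccc1)c1nc(-c2ccc(F)c(Cl)c2)no1` has not yet been measured. It is related to compound 2 by exactly the same change, (hydrogen in place of chloro on an aromatic carbon), at a place described in the same words as for compound 1 and compound 3. The difference between the core of compound 2 and the core of compound 3 is not broken down here, so whether the exchange behaves alike on both cores rests on a single prior example.

For the measured compounds named here, compound 4 is expected to show a weaker effect than compound 2 in this assay, with an estimated step of a 3.7-fold higher number from compound 2 to compound 4 (0.56 log units; beyond the scatter), because the one earlier example of this change gave a 4.9-fold higher number from compound 3 to compound 1 (0.69 log units; beyond the scatter). Taking this as a guide, with some allowance for the different core, the estimated value for compound 4 is 130000 nM, and most repeats would be expected to fall between 50000 nM and 400000 nM.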

Compound 4, half-maximal inhibitory concentration: > 100000 nM
Compound 4: no number, only a limit (the forecaster's own chance of this, stated with the estimate: 30%); the middle value does not contradict the limit.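

In this assay compound 4 gives > 100000 nM, which is a limit of the assay and not a number. Even so, the change from 4-chlorophenyl to phenyl can be read as a minimum step, an at least 2.8-fold higher number from compound 2 to compound 4 (0.44 log units; beyond the scatter), and this points the same way as a 4.9-fold higher number from compound 3 to compound 1 (0.69 log units; beyond the scatter), so in both pairs the compound without the chloro group has the weaker effect on the cells. This shows agreement in direction across just two pairs, in which the ring that loses its chloro group is not the same one, but it does not show that the change carries over with the same size: the same change on two cores in this assay, a 4.9-fold higher number (0.69 log units; beyond the scatter) from compound 3 to compound 1 and an at least 2.8-fold higher number (0.44 log units; beyond the scatter) from compound 2 to compound 4; the limit leaves it open whether they differ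

Going by these compounds, only chloro and hydrogen are seen at this place on the ring, so it remains open whether a methoxy group, a methyl group or an amine there would keep the effect of the chloro group or lose it. On these data alone, it also remains open how the change would behave on further cores, and a measured number for compound 4 in place of the limit would be needed before the two steps could be compared in size.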